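This account rests on a few compounds, and the source may have more. Where it says the series, first, only, none or still open, it means among the compounds named here.

Measured in a functional assay on HepG2 cells (Homo sapiens) for inhibition, read by MTT assay, with a stated time of 72 h; a lower number here means a stronger inhibitor, a higher number a weaker inhibitor:

- Compound 1 `COc1ccc(/C=C/C(=O)c2c(O)cc(O)cc2OC)cc1OC`: 18500 nM
- Compound 2 `COc1cc(/C=C/C(=O)c2c(O)cc(O)cc2OC)cc(OC)c1`: 17600 nM

Compound 2, at 17600 nM, stands level with compound 1, at 18500 nM. The gap between these two numbers lies within the usual scatter of repeated measurements, so neither compound can be ranked above the other.

The next compound, compound 3 `COc1cc(/C=C/C(=O)c2c(O)cc(O)cc2OC)cc(OC)c1OC`, comes from compound 2 through a single change: methoxy in place of hydrogen on an aromatic carbon. This places methoxy in place of hydrogen on an aromatic carbon, ortho to two methoxy groups and para to a large group.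

Among the compounds with values here, no measured pair yet shows what a single change does in this assay, so any forecast must be cautious and must start from compound 2 at 17600 nM. A modest move towards a lower number is expected, though it may not exceed the scatter. The expected size of the change is a 1.5-fold lower number from compound 2 to compound 3 (0.17 log units; within the scatter). For compound 3 the estimated value is 12000 nM, with an expected range from 5000 nM to 25000 nM.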

Compound 3, half-maximal inhibitory concentration: 20400 nM
Estimate against measurement, compound 3: 1.7-fold (0.23 log units) below, and the stated range covers the measured number.
By their numbers in this assay, from the lowest: compounds 2, 1 and 3 (each within the scatter of the next).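

In this assay, within the data shown here, the first single change that can be read is methoxy in place of hydrogen on an aromatic carbon, ortho to two methoxy groups and para to a large group, and the result is a 1.2-fold higher number from compound 2 to compound 3 (0.06 log units; within the scatter). The same kind of change in the other pair gives a 1.1-fold higher number from compound 1 to compound 3 (0.04 log units; within the scatter), so both steps stay inside the ordinary spread of repeated measurements and this added methoxy group leaves the number effectively unchanged in these two comparisons. No independent measurement is available to explain why this change makes so little difference.

The compounds shown leave open whether a different kind of group in this same place, such as an amine, a carboxylic acid or a longer chain, would shift the number beyond the scatter. They also leave open whether methoxy in this place would matter more if the shared core carried a change elsewhere, since these two steps cover only this one substitution on closely similar compounds.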